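Extending the saturated chain from compound 2 to compound 3

This account rests on a few compounds, and the source may have more. Where it says the series, first, only, none or still open, it means among the compounds named here.

In a functional assay on PC-3 cells (Homo sapiens) for inhibition, read by MTT assay (a lower number here means a stronger inhibitor, a higher number a weaker inhibitor), compound 1 (`CCCCCCCCCCCC(=O)OC1=C(CC=C(C)C)C(=O)c2ccccc2C1=O`) gives 27000 nM and compound 2 (`CCCCCCCCCCCCCCCC(=O)OC1=C(CC=C(C)C)C(=O)c2ccccc2C1=O`) gives 35000 nM on the shared core. Among the compounds with values here, the one measured step is a 1.3-fold higher number from compound 1 to compound 2 (0.11 log units; within the scatter) and it places compound 2 level with compound 1, with no order between them. Compound 3 (`CCCCCCCCCCCCCCCCCC(=O)OC1=C(CC=C(C)C)C(=O)c2ccccc2C1=O`) is next in the series. The difference from compound 2 is ethyl in place of hydrogen on a saturated chain carbon, ten or more bonds along the chain from a carbonyl carbon and in words it is ethyl in place of hydrogen on a saturated chain carbon, ten or more bonds along the chain from a carbonyl carbon. The step from compound 1 is the only measured one that bears on this change, since it falls in the same stretch of chain. Being a single step, it shows no trend, and nothing measured covers a chain as long as that of compound 3. Within the data shown here, with a 1.3-fold higher number from compound 1 to compound 2 (0.11 log units; within the scatter) as the sole guide, no change beyond the scatter is expected in this assay for this extension. Going by these compounds, the expected step is a 1.1-fold higher number from compound 2 to compound 3 (0.06 log units; within the scatter) and its direction stays open. The estimated value for compound 3 is 40000 nM with an expected range of 20000 nM to 80000 nM around it.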

Compound 3, half-maximal inhibitory concentration: > 100000 nM
Compound 3: a limit, no number (the forecaster's own chance of this, stated with the estimate: 25%); middle value at least 2.5-fold (0.39 log units) away from the limit.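

In this assay compound 3 stands at a limit of the assay, not at a number: the limit of > 100000 nM in this assay, at which 1 of the 3 values shown sits. The chain extension now has an effect beyond the scatter, with an at least 2.8-fold higher number from compound 2 to compound 3 (0.45 log units; beyond the scatter) and an at least 3.7-fold higher number from compound 1 to compound 3 (0.56 log units; beyond the scatter), whereas the earlier step, a 1.3-fold higher number from compound 1 to compound 2 (0.11 log units; within the scatter), showed none, so this stretch of saturated chain is not indifferent to chain length across compounds 1, 2 and 3. Both new steps are open-ended, so they give a direction and a minimum size only, and compounds 1 and 2 stay level with each other within the pattern.

Going by these compounds, whether a shorter chain than that of compound 1, which stands at 27000 nM, would give a lower number in this assay remains open. Also open, on these data alone, is whether an amine or a carboxylic acid on the chain would change the picture on the shared core, and whether the rise in number sets in gradually or abruptly between the chain lengths of compound 2 and compound 3.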